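The source may report more compounds than this note shows. Statements on the series, on what has been measured and on what is new or still open speak of the compounds shown alone.

Values in an ADME assay on HEK293 cells (Homo sapiens) for cytotoxicity, read by resazurin assay, with a stated time of 72 h (on this read-out lower numbers stand for higher toxicity in this test and higher numbers for lower toxicity in this test), for the series so far:
compound 1 (`O=C(O)c1ccc(CCOc2c(F)ccc3nc(C(=O)NCc4ccccc4)[nH]c(=O)c23)cc1`): > 20000 nM as a limit
compound 2 (`CCc1cccc(CNC(=O)c2nc3ccc(F)c(OCCc4ccc(C(=O)O)cc4)c3c(=O)[nH]2)c1`): > 20000 nM as a limit
compound 3 (`CCc1ccc(CNC(=O)c2nc3ccc(F)c(OCCc4ccc(C(=O)O)cc4)c3c(=O)[nH]2)cc1`): > 20000 nM as a limit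

Compound 2 sits at > 20000 nM in this assay and this is a limit, not a number. The series as a whole shows the limit of > 20000 nM in this assay, at which 3 of the 3 values shown sit, and offers no numerical value yet.

Compound 4 (`CCc1cccc(CNC(=O)c2nc3ccc(F)c(COCc4ccc(C(=O)O)cc4)c3c(=O)[nH]2)c1`) departs from compound 2 by a single change (((4-carboxybenzyl)oxy)methyl in place of 2-(4-carboxyphenyl)ethoxy on an aromatic carbon): ((4-carboxybenzyl)oxy)methyl in place of 2-(4-carboxyphenyl)ethoxy on an aromatic carbon, ortho to a fluoro group. The same atoms are present, joined differently.

Within the data shown here, three measured steps bear on this only loosely: a step that the two limits leave unreadable from compound 1 to compound 2 and a step that the two limits leave unreadable from compound 1 to compound 3 and a step that the two limits leave unreadable from compound 2 to compound 3 all leave the 2-(4-carboxyphenyl)ethoxy group untouched. No size can be read from any of them. With the limit of compound 2 at > 20000 nM as the only anchor, no step beyond the scatter is expected in this assay and no direction can be given. The expected step is a step that the limit leaves unreadable from compound 2 to compound 4 and the most likely report is again only a limit. For compound 4 the estimated value is 25000 nM with an expected range from 12000 nM to 50000 nM in the same read-out.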

Compound 4, half-maximal cytotoxic concentration: > 20000 nM
Compound 4: no number, only a limit; the forecaster's own chance of this, stated with the estimate: 85%; the middle value does not contradict the limit.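

In this assay compound 4 gives > 20000 nM, a limit and not a number. Compound 2 and compound 4 both carry only limits, so no new step can be read between them. The series stays at a single limit: the limit of > 20000 nM in this assay, at which 4 of the 4 values shown sit. The compounds shown leave open how far any of these structures differ in cytotoxicity in this assay.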